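A few compounds are considered here, and "the series" means these few. Any claim that something is new, unique, unknown or untested is made for them only; others in the source may bear on it.

Compound 1 `C#CCSc1nc(Nc2cccc(C(F)(F)F)c2)c(C#N)c(-c2ccccc2)n1`: in a functional assay on MCF7 cells (Homo sapiens) for inhibition, read by MTT assay, with a stated time of 72 h (a lower number here means a stronger inhibitor, a higher number a weaker inhibitor), compound 1 gives > 128000 nM, which is a limit of the assay and not a number.
Compound 2 `C#CCSc1nc(Nc2cccc(Cl)c2)c(C#N)c(-c2ccccc2)n1`: compound 2 gives > 128000 nM, again a limit of the assay.
Compound 3 `COc1ccc(Nc2nc(SCc3cn(Cc4ccccc4Cl)nn3)nc(-c3ccccc3)c2C#N)cc1`: compound 3 gives 8050 nM.

Among the compounds with values here, compound 3 therefore stands as the only real number among the three; the other two sit at the limit of > 128000 nM in this assay, at which 2 of the 3 values shown sit. Within the data shown here, the one single-point step, a step that the two limits leave unreadable from compound 1 to compound 2, cannot be sized because both ends are limits. Compound 4 `Cc1cccc(Nc2nc(SCc3cn(Cc4ccccc4Cl)nn3)nc(-c3ccccc3)c2C#N)c1` differs from compound 3 by 3-methylphenyl in place of 4-methoxyphenyl on a nitrogen on an aromatic ring. Among the measured compounds shown here, no measured step touches this position, so no direction can be read from the data. The expectation for compound 4 is a value close to that of compound 3, a step of a 1.5-fold higher number from compound 3 to compound 4 (0.17 log units; within the scatter), with compound 4 estimated at 12000 nM and a range from 4000 nM to 40000 nM.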

Compound 4, half-maximal inhibitory concentration: 19600 nM
The estimate for compound 4 lay 1.6-fold (0.21 log units) below the measured number; the range from low to high includes it.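

Within the data shown here, this is the first readable step at the group on the amino nitrogen: in this assay 3-methylphenyl in place of 4-methoxyphenyl gives a 2.4-fold higher number from compound 3 to compound 4 (0.39 log units; beyond the scatter) and so shows that this position responds to the change, if only modestly. Nothing measured here says why the number moves.

The change alters both the group and where it sits on the phenyl ring, so these two parts cannot be told apart; 4-methylphenyl or 3-methoxyphenyl would separate them. From the compounds shown here alone, how a phenyl ring carrying an amine or a carboxylic acid would read here stays open.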